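This account rests on a few compounds, and the source may have more. Where it says the series, first, only, none or still open, it means among the compounds named here.

Working notes on the series. In an assay on HEK-Blue hTLR8 cells for agonist activity at Toll-like receptor 8 (Homo sapiens), read by reporter gene assay and spectrophotometry (on this read-out higher numbers stand for an effect only at larger amounts of compound and lower numbers for an effect already at smaller amounts), compound 1 `CCCC#Cc1cc2ccccc2nc1N` gives 13000 nM, compound 2 `C=CCCCc1cc2ccccc2nc1N` gives 490 nM, and compound 3 `CCCCNc1cc2ccccc2nc1N` gives 4280 nM. Compound 2 thus has the lowest number of the three, with an 8.7-fold higher number from compound 2 to compound 3 (0.94 log units; beyond the scatter) and a 27-fold lower number from compound 1 to compound 2 (1.42 log units; beyond the scatter) setting the gaps. Compound 4 `CCC/C=C/c1cc2ccccc2nc1N` differs from compound 2 by pent-1-en-1-yl in place of pent-4-en-1-yl on an aromatic carbon. The step that bears on this is a 27-fold lower number from compound 1 to compound 2 (1.42 log units; beyond the scatter), which pairs a change of the triple bond to a double bond with a move of the unsaturation within the chain; compound 4 keeps the double bond but returns it to the pent-1-en-1-yl arrangement, so in this assay a modest rise in the number from compound 2 to compound 4 is expected, a 3.1-fold higher number from compound 2 to compound 4 (0.49 log units; beyond the scatter). Compound 4 is estimated at 1500 nM, within 400 nM to 6000 nM.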

Compound 4, half-maximal effective concentration: 2670 nM
The estimate for compound 4 lay 1.8-fold (0.25 log units) below the measured number, within the range that was stated.
By their numbers in this assay, from the lowest: compound 2; then compounds 4 and 3 (each within the scatter of the next); then compound 1.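

In this assay the place of the double bond counts on its own: pent-1-en-1-yl in place of pent-4-en-1-yl, with the same atoms, gives a 5.4-fold higher number from compound 2 to compound 4 (0.74 log units; beyond the scatter) on the same aromatic carbon. Pent-1-en-1-yl in place of pent-1-yn-1-yl accounts for only part of the larger gap in this series, with a 4.9-fold lower number from compound 1 to compound 4 (0.69 log units; beyond the scatter) at this position. Pent-1-en-1-yl and butylamino cannot be told apart, at a 1.6-fold lower number from compound 3 to compound 4 (0.20 log units; within the scatter) on this carbon.

No available data explain these steps. Open, as far as these compounds go, is how a saturated pentyl chain or a longer alkenyl chain would read at this position.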